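Estimating an Ester Analogue of a DDX3X Inhibitor

This account rests on a few compounds, and the source may have more. Where it says the series, first, only, none or still open, it means among the compounds named here.

The compounds here share a core in which a phenyl-substituted urea is joined to a triazole that carries a short side chain. Compound 1 `O=C(O)CCc1cn(-c2ccc(NC(=O)Nc3ccccc3C(F)(F)F)cc2)nn1` carries a 2-carboxyethyl chain on the triazole; in an assay on isolated protein for inhibition of ATP-dependent RNA helicase DDX3X (Homo sapiens), read by FRET, with stated times of 30 s and 40 min (a lower number here means a stronger inhibitor, a higher number a weaker inhibitor), compound 1 gives "not determined" (no result reported), so it offers no number of its own. Two neighbours with different substituents set the scale. Compound 2 `CCCCc1cn(-c2ccc(NC(=O)Nc3cc(OC4CCOC4)ccc3C)cc2)nn1`, with a butyl chain on the triazole, gives 100 nM in this assay. Compound 3 `Cc1ccccc1NC(=O)Nc1ccc(-n2cc(CCCN3CCN(C)CC3)nn2)cc1`, whose chain ends in a methylpiperazine, gives 40100 nM in this assay, a far weaker result than compound 2, though the two differ in more than one place.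

Compound 4 `CC(C)CC(=O)OCCc1cn(-c2ccc(NC(=O)Nc3ccccc3C(F)(F)F)cc2)nn1` is the ester analogue of compound 1. The change is (isobutylcarbonyl)oxy in place of carboxy on a saturated chain carbon, two bonds along the chain from an aromatic carbon. Among the measured compounds shown here, because compound 1 has no measured value, no step can be computed, and its direction cannot be read from a matched pair. Among the measured compounds, compound 2 with its butyl chain sits at the strong end and compound 3 with its chain ending in a methylpiperazine at the weak end; an ester lies structurally apart from both. Compound 4 is therefore expected to fall at 1500 nM, with a wide range from 200 nM to 10000 nM.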

Compound 4, half-maximal inhibitory concentration: 400 nM
Compound 4: middle estimate off by 3.8-fold (0.57 log units), on the high side, and the stated range covers the measured number.
By their numbers in this assay, from the lowest: compound 2; then compound 4; then compound 3.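

No step can be read from this result: compound 4 differs from compound 1 in one place, but compound 1 has no single number to compare. The compounds shown leave open how the change from carboxy to (isobutylcarbonyl)oxy shifts inhibition of DDX3X. Nothing here offers an explanation for the value of compound 4.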